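The source may hold more compounds than are shown below. What is called first, only, known or untested is meant among the compounds shown, and "the series" means these compounds.

Measured so far in a functional assay on the whole organism (strain Wistar) for inhibition, with Rattus norvegicus as the target, read by paw edema, with stated times of 1 h and 24 h, at a dose of 10 mg/kg by the intraperitoneal route; a lower number here means less inhibition, a higher number more inhibition at the dose given (going by the name of the read-out):

- compound 1 `COc1cc(/C=C/C(=O)/C=C(O)/C=C/c2ccc(OC(=O)[C@@H](C)NC(=O)OC(C)(C)C)c(OC)c2)ccc1OC(=O)[C@@H](C)NC(=O)OC(C)(C)C` gives 37%
- compound 2 `COc1cc(/C=C/C(=O)/C=C(O)/C=C/c2ccc(OC(=O)[C@H](CCSC)NC(=O)OC(C)(C)C)c(OC)c2)ccc1OC(=O)[C@H](CCSC)NC(=O)OC(C)(C)C` gives 23%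
- compound 3 `COc1cc(/C=C/C(=O)/C=C(O)/C=C/c2ccc(OC(=O)C(C)NC(=O)OCc3ccccc3)c(OC)c2)ccc1OC(=O)C(C)NC(=O)OCc1ccccc1` gives 100%

Compound 3 stands highest of the three numbers in this assay. Its nearest neighbour is compound 1, whose number lies lower by a gap that is beyond the scatter; compound 2 lies further still, also beyond the scatter. No two of the measured compounds differ in only one place, so no single-change step can be read from them; only the raw values can be set side by side.

The next compound, compound 4 `COc1cc(/C=C/C(=O)/C=C(O)/C=C/c2ccc(OC(=O)[C@@H](C)NC(=O)OCc3ccccc3)c(OC)c2)ccc1OC(=O)[C@@H](C)NC(=O)OCc1ccccc1`, has the same atoms and bonds as compound 3. The change is the two compounds have the same atoms and bonds; at least one stereo element is drawn with a configuration in one of them and without one in the other: 2 of 5 stereo elements differ; a stereocentre at a saturated chain carbon is drawn without a configuration in compound 3 and R in compound 4; a stereocentre at a saturated chain carbon is drawn without a configuration in compound 3 and R in compound 4.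

Going by the values given here, since no step between measured compounds is available, the expectation rests on the structural relation alone: compound 4 is either the same material as compound 3 with its configuration stated, or one defined isomer of it. Compound 4 is therefore expected to give a number close to that of compound 3 in this assay, with the step of a number 15 percentage points lower from compound 3 to compound 4 (beyond the scatter) expected to be none beyond the scatter or a modest drop. The estimate for compound 4 is 85%, with a range from 60% to 100%.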

Compound 4, a percentage reported as inhibition, in the whole organism at one dose (the size of the read-out at that dose, not a potency): 49%
Compound 4: the middle estimate sits 36 percentage points above what was measured; the whole stated range lies above it.
By their numbers in this assay, from the lowest: compound 2; then compound 1; then compound 4; then compound 3.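

In this assay, going by these compounds alone, the stereocentres at the two saturated chain carbons give the first single-change reading, and the step is a number 51 percentage points lower from compound 3 to compound 4 (beyond the scatter). Atoms and bonds stay the same, so the response at this dose is not fixed by the constitution alone: drawing both of these centres as R goes with a clearly lower number than leaving them without a stated configuration. The comparison therefore shows that these two positions cannot be treated as indifferent to how their configuration is defined, and the only structural difference available to set against the step is this one: the fact that one of compounds 3 and 4 is drawn with a defined configuration and the other without, at the place where they differ

The compounds shown leave open what compound 3 contains at these centres, and so whether the opposite configuration would carry the higher number. They also leave open how the number would respond if the carbamate gave way to a free amine, or if the methyl side chain at these centres gave way to a longer chain with its configuration defined.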